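Changing the ring on the carbon double-bonded to nitrogen

The source may hold more compounds than are shown below. What is called first, only, known or untested is meant among the compounds shown, and "the series" means these compounds.

Three compounds have been measured in a functional assay on HT-29 cells (Homo sapiens) for cytotoxicity, read by MTT assay, with a stated time of 72 h; on this read-out lower numbers stand for stronger inhibition and higher numbers for weaker inhibition:

Compound 1 `CN(C)CCn1cnnc1-c1cc(Oc2ccc(NC(=O)N/N=C/c3ccc(O)c(O)c3)cc2F)ccn1`: 1890 nM
Compound 2 `CN(C)CCn1cnnc1-c1cc(Oc2ccc(NC(=O)N/N=C/c3cc(Br)c(O)c(Br)c3)cc2F)ccn1`: 2670 nM
Compound 3 `CN(C)CCn1cnnc1-c1cc(Oc2ccc(NC(=O)N/N=C/c3c[nH]c4ccccc34)cc2F)ccn1`: 1300 nM

All three share one core and differ only in the ring attached to the carbon with a double bond to nitrogen. Compound 3 gives the lowest of the three numbers, but its gap to compound 1 is small: a 1.5-fold lower number from compound 1 to compound 3 (0.16 log units; within the scatter). Its gap to compound 2 is somewhat larger: a 2.1-fold lower number from compound 2 to compound 3 (0.31 log units; beyond the scatter). Between the other two the step is a 1.4-fold higher number from compound 1 to compound 2 (0.15 log units; within the scatter).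

Compound 4 `CN(C)CCn1cnnc1-c1cc(Oc2ccc(NC(=O)N/N=C/c3ccccc3O[N+](=O)[O-])cc2F)ccn1` carries the same change in the same place, with 2-(nitrooxy)phenyl in place of 1H-indol-3-yl on a carbon with a double bond to nitrogen.

The two measured steps that swap a ring at this position, from compound 1 to compound 3 and from compound 2 to compound 3, were both small, and the third step was within the scatter. Nothing measured points to a large move in either direction for compound 4 in this assay. The step this estimate means is a 1.4-fold higher number from compound 3 to compound 4 (0.14 log units; within the scatter), an expectation only. Compound 4 is therefore expected to come out near 1800 nM, with a range from 800 nM to 4500 nM.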

Compound 4, half-maximal inhibitory concentration: 950 nM
The estimate for compound 4 lay 1.9-fold (0.28 log units) above the measured number; the measured number falls inside the stated range.
By their numbers in this assay, from the lowest: compounds 4, 3, 1 and 2 (each within the scatter of the next, the first and the last beyond it).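

Swapping 1H-indol-3-yl, which carries a hydrogen-bond donor, for 2-(nitrooxy)phenyl, which carries hydrogen-bond acceptors and no donor, leaves the number unchanged within the scatter, with a 1.4-fold lower number from compound 3 to compound 4 (0.14 log units; within the scatter). Among these compounds, the same ring also sits within the scatter of the catechol-type ring of compound 1, with a 2.0-fold lower number from compound 1 to compound 4 (0.30 log units; within the scatter), but it stands clearly apart from the dibrominated ring, with a 2.8-fold lower number from compound 2 to compound 4 (0.45 log units; beyond the scatter), a modest gap that adds a second ring to the one earlier step beyond the scatter, so that compound 2 now differs from both compound 3 and compound 4. This position therefore tolerates rings of quite different make with only modest movement in the number, and no measurement is at hand to explain why these rings read so alike.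

As far as these compounds go, what a plain phenyl ring would give remains open, so the share of the nitrooxy group in the number of compound 4 cannot be separated from that of the ring carrying it. Also open, from the compounds shown here alone, is how a ring bearing an amine or a carboxylic acid, or a longer alkyl chain at this position, would compare.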